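A Further Methyl on Compound 2

The source may hold more compounds than are shown below. What is called first, only, known or untested is meant among the compounds shown, and "the series" means these compounds.

Of the compounds shown here, two sharing one core have been measured in a functional assay on KBVIN cells (Homo sapiens) for antiproliferative activity, read by sulforhodamine B assay, with a stated time of 3 days; on this read-out higher numbers stand for an effect only at larger amounts of compound and lower numbers for an effect already at smaller amounts. Compound 1 `CCC1=C(O)c2c(oc(-c3ccc(SC)cc3)cc2=O)C(CC)(CC)C1=O` gives 1.38 uM, and compound 2 `CCC1=C(O)c2c(oc(-c3ccc(OC)cc3C)cc2=O)C(CC)(CC)C1=O` gives 2.62 uM, which places the two within the scatter of each other. Compound 3 `CCC1=C(O)c2c(oc(-c3cc(C)c(OC)cc3C)cc2=O)C(CC)(CC)C1=O` departs from compound 2 by a single change, methyl in place of hydrogen on an aromatic carbon, ortho to a methoxy group and para to a methyl group. Going by the values given here, only one measured step bears on this change, a 1.9-fold higher number from compound 1 to compound 2 (0.28 log units; within the scatter), in which 4-methoxy-2-methylphenyl replaces 4-(methylsulfanyl)phenyl. Among the compounds with values here, no measured pair isolates the added methyl alone, so the evidence is thin. With that single small step as the guide, no shift beyond the scatter is expected in this assay. The expected step is a 1.0-fold lower number from compound 2 to compound 3 (0.02 log units; within the scatter). For compound 3 the estimate is 2.5 uM, with an expected range from 1 uM to 6 uM.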

Compound 3, concentration for half-maximal effect: 7.58 uM
Compound 3: the middle estimate sits 3.0-fold (0.48 log units) below what was measured; the whole stated range lies below it.
By their numbers in this assay, from the lowest: compounds 1 and 2 (each within the scatter of the next); then compound 3.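

Methyl in place of hydrogen on this aromatic carbon, ortho to a methoxy group and para to a methyl group, gives a 2.9-fold higher number from compound 2 to compound 3 (0.46 log units; beyond the scatter) in this assay and is the one step here that lies beyond the scatter. This position therefore responds to the addition of a single methyl, which the earlier pair could not show, and the change goes toward an effect only at larger amounts of compound. No measurement given here accounts for this shift.

As far as these compounds go, whether the same step would follow from another group on this carbon, such as fluorine, a hydroxyl or an amine, remains open. From the compounds shown here alone, it also remains open whether a methyl added to the 4-(methylsulfanyl)phenyl group of compound 1 would give a step of like size.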